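A few compounds are considered here, and "the series" means these few. Any claim that something is new, unique, unknown or untested is made for them only; others in the source may bear on it.

Two compounds of the series have numbers in an assay for binding affinity to adenosine receptor A1 (Bos taurus) (on this read-out higher numbers stand for weaker inhibition and lower numbers for stronger inhibition), so far. Compound 1 `CCn1c(=O)c2nc(-c3ccc(S(=O)(=O)N4CCOCC4)cc3)[nH]c2n(CC)c1=O` gives 13 nM. Among the measured compounds shown here, compound 2 `CCn1c(=O)c2nc(-c3ccc(S(=O)(=O)N4CCSCC4)cc3)[nH]c2n(CC)c1=O` gives 36.6 nM; it stands at the higher of the two numbers, and the single measured step, a 2.8-fold higher number from compound 1 to compound 2 (0.45 log units; beyond the scatter), separates it from compound 1. Compound 3 `CCn1c(=O)c2nc(-c3ccc(S(=O)(=O)NCCCN(C)C)cc3)[nH]c2n(CC)c1=O` is the next member; its change from compound 2 is (3-(dimethylamino)propyl)amino in place of thiomorpholin-4-yl on a sulfonyl sulfur. For the measured compounds named here, no measured step covers an exchange of this kind: the one step available swaps one six-membered ring for another on the same sulfonyl sulfur, whereas here the ring leaves altogether and an open chain with a hydrogen-bond donor enters. The step is therefore expected to stay modest in this assay, with direction open, so for compound 3 an estimated step of a 1.2-fold lower number from compound 2 to compound 3 (0.09 log units; within the scatter) is assumed. The estimate for compound 3 in this assay is 30 nM, with a range from 8 nM to 110 nM.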

Compound 3, half-maximal inhibitory concentration: 1.6 nM
The estimate for compound 3 lay 19-fold (1.27 log units) above the measured number; the whole stated range lies above it.
By their numbers in this assay, from the lowest: compound 3; then compound 1; then compound 2.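

On a sulfonyl sulfur, replacing a ring with the open chain (3-(dimethylamino)propyl)amino gives a 23-fold lower number from compound 2 to compound 3 (1.36 log units; beyond the scatter) in this assay and an 8.1-fold lower number from compound 1 to compound 3 (0.91 log units; beyond the scatter) there too. The ring is therefore not needed for the lowest number of the three, and this position can move the number much further than the ring exchange alone suggested. Nothing available bears on why the open chain gives this result.

From the compounds shown here alone, the change removes the ring and brings in the hydrogen-bond donor, the propyl chain and the terminal dimethylamino group all at once, so which of these carries the step stays open. A plain propylamino chain, a longer chain ending in dimethylamino, or a piperazine ring on the same sulfonyl sulfur would help separate these contributions.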